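The source may hold more compounds than are shown below. What is called first, only, known or untested is meant among the compounds shown, and "the series" means these compounds.

Measured so far in a functional assay on U-373MG ATCC cells (Homo sapiens) for inhibition, read by MTT assay, with a stated time of 72 h; on this read-out lower numbers stand for stronger inhibition and higher numbers for weaker inhibition:
- compound 1 `CC1(C)CC(NC(=O)NCc2ccccc2)c2cc(Br)ccc2O1`: 27000 nM
- compound 2 `CC(C)NC(=S)NC1CC(C)(C)Oc2ccc(Cl)cc21`: 57000 nM
- compound 3 `CC(C)NC(=O)NC1CC(C)(C)Oc2ccc(Cl)cc21`: 62000 nM

Compound 2 lies within the scatter of compound 3, while compound 1 shows a lower number, beyond the scatter. Compound 4 `CC1(C)CC(NC(=S)Nc2cccc(C#N)c2)c2cc(Cl)ccc2O1` differs from compound 2 as follows: 3-cyanophenyl in place of isopropyl on an amide-type nitrogen. Among the compounds with values here, the only measured step, a 1.1-fold higher number from compound 2 to compound 3 (0.04 log units; within the scatter), exchanges sulfur for oxygen and leaves the isopropyl in place, so it says little about this change. Compound 1 also has a ring-bearing group on an amide-type nitrogen and gives 27000 nM, though it differs elsewhere too. A modest move toward a lower number is therefore expected, and the expected step is a 2.3-fold lower number from compound 2 to compound 4 (0.36 log units; beyond the scatter). For compound 4 the estimate is 25000 nM, with an expected range of 8000 nM to 60000 nM.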

Compound 4, half-maximal inhibitory concentration: 7000 nM
The estimate for compound 4 lay 3.6-fold (0.55 log units) above the measured number; the whole stated range lies above it.
By their numbers in this assay, from the lowest: compound 4; then compound 1; then compounds 2 and 3 (each within the scatter of the next).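

In this assay, the amide-type nitrogen bearing the thiocarbonyl carbon proves sensitive to its substituent: 3-cyanophenyl in place of isopropyl gives an 8.1-fold lower number from compound 2 to compound 4 (0.91 log units; beyond the scatter), the first single change shown to move the number beyond the scatter. The exchange of sulfur for oxygen, a 1.1-fold higher number from compound 2 to compound 3 (0.04 log units; within the scatter), had not done so. No measurement here accounts for the step.

From the compounds shown here alone, it remains open whether the ring alone or the nitrile carries this step, which a plain phenyl on that nitrogen would separate. Also open, going by these compounds, is how a methoxy group or a carboxylic acid in place of the nitrile would read.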